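A methyl group leaves the aryl amide of compound 1

A few compounds are considered here, and "the series" means these few. Any claim that something is new, unique, unknown or untested is made for them only; others in the source may bear on it.

compound 1 `C=C1CCC[C@]2(C)CCC(c3cn(CC(=O)Nc4ccc(C)cc4)nn3)=CC[C@@]12C` gives 80100 nM
compound 2 `C=C1CCC[C@]2(C)CCC(c3cn(-c4ccc(Cl)cc4)nn3)=CC[C@@]12C` gives 35100 nM

In a functional assay on MCF7 cells (Homo sapiens) for cytotoxicity, read by MTT assay, with a stated time of 48 h (on this read-out lower numbers stand for stronger inhibition and higher numbers for weaker inhibition), compound 1 gives 80100 nM and compound 2 gives 35100 nM in this measurement. The gap between these two numbers lies outside the usual scatter, with compound 1 the higher of the two. Compound 3 `C=C1CCC[C@]2(C)CCC(c3cn(CC(=O)Nc4ccccc4)nn3)=CC[C@@]12C` awaits measurement. Its change from compound 1 is hydrogen in place of methyl on an aromatic carbon and amounts to hydrogen in place of methyl on an aromatic carbon. Among the measured compounds shown here, no measured pair shows this change, so no step beyond the scatter is expected in this assay in either direction. The estimated 1.1-fold lower number from compound 1 to compound 3 (0.06 log units; within the scatter) is accordingly small. For compound 3 the expected value is 70000 nM within a range of 30000 nM to 160000 nM in this measurement.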

Compound 3, half-maximal inhibitory concentration: 148000 nM
Compound 3: the middle estimate sits 2.1-fold (0.33 log units) below what was measured, and the stated range covers the measured number.
By their numbers in this assay, from the lowest: compound 2; then compounds 1 and 3 (each within the scatter of the next).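

In this assay, among the compounds shown here, hydrogen in place of methyl on an aromatic carbon gives a 1.8-fold higher number from compound 1 to compound 3 (0.27 log units; within the scatter), the first measured pair for this change. At this position, para to a large group, going from 4-methylphenyl to phenyl therefore does not separate the two compounds in this assay. Nothing measured here bears on what lies behind the step.

As far as these compounds go, whether a methoxy group, a chlorine atom or an amine at this position would move the number beyond the scatter stays open. Compound 2 differs from compound 1 and compound 3 in more than one place, so it does not address this question.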